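Changing the amide end group of compound 2

A few compounds are considered here, and "the series" means these few. Any claim that something is new, unique, unknown or untested is made for them only; others in the source may bear on it.

Measured in a functional assay on DU-145 cells (Homo sapiens) for antiproliferative activity, read by sulforhodamine B assay, with a stated time of 48 h; a higher number here means a weaker inhibitor, a lower number a stronger inhibitor:
Compound 1 `COc1ccc(-c2oc3c(OC)c(OC)cc(OCCCC(=O)NCc4ccccn4)c3c(=O)c2O)cc1`: > 40000 nM
Compound 2 `COc1ccc(-c2oc3c(OC)c(OC)cc(OCCCCCC(=O)N4CCN(C)CC4)c3c(=O)c2O)cc1`: 13200 nM

Compound 1 stands at > 40000 nM, which is a limit of the assay and not a number. Going by the values given here, compound 2, at 13200 nM, therefore holds the only true number so far.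

Compound 3 `COc1ccc(-c2oc3c(OC)c(OC)cc(OCCCCCC(=O)NCc4ccccn4)c3c(=O)c2O)cc1` has not yet been measured. It differs from compound 2 at the end of the chain: ((pyridin-2-yl)methyl)amino in place of 4-methylpiperazin-1-yl on a carbonyl carbon. In words, this is ((pyridin-2-yl)methyl)amino in place of 4-methylpiperazin-1-yl on a carbonyl carbon.

Among the compounds with values here, only one measured step bears on this change: an at least 3.0-fold lower number from compound 1 to compound 2 (0.48 log units; beyond the scatter). That step alters the chain and the end group together, so it cannot separate the two. Compound 3 pairs the end group of compound 1 with the chain of compound 2, so part of that step may be lost. A small rise in the number is expected in this assay, one that may stay within the scatter. The estimated change is a 1.5-fold higher number from compound 2 to compound 3 (0.18 log units; within the scatter). Compound 3 is expected at 20000 nM, with an estimated range of 8000 nM to 40000 nM.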

Compound 3, half-maximal inhibitory concentration: > 40000 nM
Compound 3 was reported as a limit; the forecaster's own chance of this, stated with the estimate: 30%; at least 2.0-fold (0.30 log units) between middle value and limit.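

With the chain held as in compound 2, changing the end group alone gives an at least 3.0-fold higher number from compound 2 to compound 3 (0.48 log units; beyond the scatter) in this assay, so the group on the carbonyl carbon matters in its own right, which the earlier step, with chain and end group altered together, could not show. On these data alone, the true size of this step remains unknown, as compound 3 gives > 40000 nM, which is a limit of the assay and not a number. The effect of the chain alone, the only difference between compound 1 and compound 3, cannot be read, since both values are limits: the limit of > 40000 nM in this assay, at which 2 of the 3 values shown sit.

The compounds shown leave open which part of the 4-methylpiperazin-1-yl group carries the difference, a question that a morpholine amide or a piperazine amide without the methyl group on the same chain could address. They also leave open how chain length acts when the 4-methylpiperazin-1-yl amide is kept fixed, which a shorter or a longer chain carrying that amide could settle.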